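The source may report more compounds than this note shows. Statements on the series, on what has been measured and on what is new or still open speak of the compounds shown alone.

Measured so far:
compound 1, `C=CC1C(=O)N(c2cc(OC)c(OC)c(OC)c2)C1c1ccc(OC)cc1` — 33 nM
compound 2, `COc1ccc(C2C(O)C(=O)N2c2cc(OC)c(OC)c(OC)c2)cc1` — 13 nM
compound 3, `COc1ccc(C2C(C3CC3)C(=O)N2c2cc(OC)c(OC)c(OC)c2)cc1` — 156 nM

These three compounds share one core and differ only in the group carried on a saturated ring carbon. In a functional assay on HL-60 cells (Homo sapiens) for inhibition, read by resazurin assay, with a stated time of 72 h (a lower number here means a stronger inhibitor, a higher number a weaker inhibitor), compound 2 gives 13 nM, the lowest of the three numbers, and its steps to both neighbours lie beyond the scatter, so it is the strongest inhibitor of the set: a 2.5-fold lower number from compound 1 to compound 2 (0.40 log units; beyond the scatter), a 12-fold higher number from compound 2 to compound 3 (1.08 log units; beyond the scatter), and between the other two a 4.7-fold higher number from compound 1 to compound 3 (0.67 log units; beyond the scatter).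

Compound 4, `COc1ccc(C2C(O)C(=O)N2c2cc(OC)c(OC)c(OC)c2)cc1O`, keeps the hydroxy on the saturated ring carbon and differs from compound 2 at another place: hydroxy in place of hydrogen on an aromatic carbon. Within the data shown here, every measured step concerns the saturated ring carbon; none touches the aromatic ring that changes here, so no comparable step is available. With nothing to point either way, the expectation for compound 4 is a number close to that of compound 2, a step of a 1.1-fold lower number from compound 2 to compound 4 (0.03 log units; within the scatter) not expected to exceed the scatter, held with wide uncertainty. Compound 4 is accordingly estimated at 12 nM, within 3 nM to 50 nM.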

Compound 4, half-maximal inhibitory concentration: 5 nM
The estimate for compound 4 lay 2.4-fold (0.38 log units) above the measured number, and the stated range covers the measured number.
By their numbers in this assay, from the lowest: compound 4; then compound 2; then compound 1; then compound 3.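

In this assay, the aromatic ring proves to be a second place where a small change moves the number: hydroxy in place of hydrogen, ortho to a methoxy group, gives a 2.6-fold lower number from compound 2 to compound 4 (0.41 log units; beyond the scatter). All earlier steps concerned the saturated ring carbon, whereas this one shows that the 4-methoxyphenyl to 3-hydroxy-4-methoxyphenyl change can lower the number further while the hydroxy on that carbon stays in place, leaving compound 4 with the lowest number of the four. No supporting data are available to explain this step.

The compounds shown leave open whether the same aromatic change would lower the number with the vinyl of compound 1 or the cyclopropyl of compound 3 on the saturated ring carbon. They also leave open how an amine, a fluorine or an ethoxy would compare with hydroxy on that aromatic carbon.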